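Nitro in Place of Ethylamino: An Expected Loss

The source may hold more compounds than are shown below. What is called first, only, known or untested is meant among the compounds shown, and "the series" means these compounds.

Measured so far:
compound 1, `CCOC(=O)C(=O)Nc1cc(N(C)C)ccc1C#N`: > 100 mg/kg
compound 2, `CCNc1cccc(NC(=O)C(=O)OCC)c1C#N`: 0.03 mg/kg

In a functional assay on the whole organism with Rattus norvegicus as the target (a lower number here means that less compound is needed, a higher number that more compound is needed for the effect), compound 1 gives > 100 mg/kg, which is a limit of the assay and not a number. Compound 1 therefore sits at the limit of > 100 mg/kg in this assay, at which 1 of the 2 values shown sits. Among the compounds with values here, compound 2 gives 0.03 mg/kg in this assay and so holds the only numerical value among the two compounds. Within the data shown here, compound 1 and compound 2 differ from each other in more than one place, so no single step between them is counted, and their two values show only that one compound lies at a limit while the other gives a number.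

The next compound, compound 3, `CCOC(=O)C(=O)Nc1cccc([N+](=O)[O-])c1C#N`, is not yet measured in this assay. It differs from compound 2 in one place: nitro in place of ethylamino on an aromatic carbon.

Among the measured compounds shown here, with no measured step to rest on, the author expects the step from compound 2 to compound 3 in this assay to be a loss beyond the scatter, of about a 33-fold higher number from compound 2 to compound 3 (1.52 log units; beyond the scatter). Compound 3 is accordingly expected to give roughly 1 mg/kg in this assay, with a range from 0.05 mg/kg to 30 mg/kg.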

Compound 3, dose for half-maximal effect: 82 mg/kg
Estimate against measurement, compound 3: 82-fold (1.91 log units) below; the measured number lies above the stated range.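

In this assay, within the data shown here, the carbon ortho to a cyano group on the shared core proves highly sensitive to the group it carries: putting nitro in place of ethylamino gives a 2700-fold higher number from compound 2 to compound 3 (3.44 log units; beyond the scatter) and is the only step in this set that can be read. The exchange keeps the count at 3 heavy atoms, so activity at this position is not set by the number of heavy atoms alone. What does change, as counted, is the atoms themselves and the hydrogen-bond donor of ethylamino, which nitro does not have, but nothing measured here accounts for the size of the loss.

With one step at this place, the compounds shown leave open whether the change owes more to the departure of ethylamino or to the arrival of nitro. On these data alone, a primary amine, a methoxy group or a longer chain such as butylamino on the same carbon would help separate those two readings, and whether the step holds on another core also remains open.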